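The source may hold more compounds than are shown below. What is called first, only, known or untested is meant among the compounds shown, and "the series" means these compounds.

Series notes. In an in vitro functional assay on cells for agonist activity at Bombesin receptor subtype-3 (Homo sapiens), read by luminescence and calcium flux (on this read-out higher numbers stand for an effect only at larger amounts of compound and lower numbers for an effect already at smaller amounts), compound 2 `O=C(O)c1ccccc1-c1ccc(CCc2ncc(CC3CCCCCC3)[nH]2)cc1` gives 88 nM, the lowest number among the three measured compounds. Compound 1 `O=C(O)c1ccccc1-c1ccc(CCc2ncc(Cc3ccccc3F)[nH]2)cc1` gives 177 nM; the step of a 2.0-fold lower number from compound 1 to compound 2 (0.30 log units; within the scatter) is within the scatter, so compounds 1 and 2 cannot be ordered against each other. Compound 3 `CC(C)(C)c1cnc(CCc2ccc(-c3ccccc3C(=O)O)cc2)[nH]1` gives 4330 nM; the steps of a 24-fold higher number from compound 1 to compound 3 (1.39 log units; beyond the scatter) and a 49-fold higher number from compound 2 to compound 3 (1.69 log units; beyond the scatter) are both large and beyond the scatter, and they concern the tert-butyl group on an aromatic carbon, a different place from the change now considered.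

Compound 4 `Cc1ccc(Cc2cnc(CCc3ccc(-c4ccccc4C(=O)O)cc3)[nH]2)cc1` is not yet measured in this assay. It differs from compound 2 by 4-methylphenyl in place of cycloheptyl on a saturated chain carbon bound to an aromatic carbon. For the measured compounds named here, the one measured step that bears on this is the exchange of 2-fluorophenyl for cycloheptyl at the same saturated chain carbon, which moved the number by a 2.0-fold lower number from compound 1 to compound 2 (0.30 log units; within the scatter), within the scatter. Compound 4 brings an aromatic ring back to that place, so the expected step is a 1.7-fold higher number from compound 2 to compound 4 (0.23 log units; within the scatter), not beyond the scatter. Compound 4 is therefore expected to give 150 nM, with a range of 50 nM to 500 nM.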

Compound 4, half-maximal effective concentration: 2660 nM
Beside the measured number, compound 4's estimate is 18-fold (1.25 log units) below it, outside the stated range (above it).
By their numbers in this assay, from the lowest: compounds 2 and 1 (each within the scatter of the next); then compounds 4 and 3 (each within the scatter of the next).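

In this assay the group on the saturated chain carbon bound to an aromatic carbon proves sensitive to more than ring type, as both a 15-fold higher number from compound 1 to compound 4 (1.18 log units; beyond the scatter) and a 30-fold higher number from compound 2 to compound 4 (1.48 log units; beyond the scatter) are large, the second with the same heavy-atom count on both sides of the exchange. With a 1.6-fold lower number from compound 3 to compound 4 (0.21 log units; within the scatter) compound 4 cannot be ordered against compound 3, so among the aromatic groups here 4-methylbenzyl does not keep the lower number seen with 2-fluorobenzyl in compound 1, and an aromatic ring alone does not decide the result. Nothing available gives a reason for the gap between 2-fluorophenyl and 4-methylphenyl.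

On these data alone, whether plain phenyl at this place would fall with compound 1 or with compound 4 stays open. So does whether 2-methylphenyl, or a phenyl ring carrying an amine, would separate the kind of substituent from its place on the ring.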